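This account rests on a few compounds, and the source may have more. Where it says the series, first, only, none or still open, it means among the compounds named here.

Compound 3 `CCOC(=O)c1ccc(CO/N=C/c2c(C)nn(C)c2Oc2ccc(Cl)cc2)cc1` carries an ethoxycarbonyl on the benzyl ring of a shared core; in a functional assay on HepG2 cells (Homo sapiens) for antiproliferative activity, tested at 1 uM (on this read-out higher numbers stand for more inhibition at the one concentration tested (going by the name of the read-out) and lower numbers for less inhibition), compound 3 gives 27.4%. Among the three numbers that stand so far it is the second highest. Among the measured compounds shown here, its nearest neighbour is compound 2 `Cc1ccc(CO/N=C/c2c(C)nn(C)c2Oc2ccc(Cl)cc2)cc1`, which in this assay gives 31.3%, and the only one-place step recorded, a number 3.9 percentage points lower from compound 2 to compound 3 (within the scatter), lies within the scatter. Far from it stands compound 1 `Cc1c(CO/N=C/c2c(-c3ccccc3)nn(-c3ccccc3)c2Oc2ccc(Cl)cc2)cccc1-c1ccccc1`, which in this assay gives -14.8% and differs from compound 3 in several places at once.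

Compound 4 `Cc1nn(C)c(Oc2ccc(Cl)cc2)c1/C=N/OCc1ccc(C(F)(F)F)cc1` is compound 3 with a trifluoromethyl in place of the ethoxycarbonyl, the exact difference being (trifluoromethyl in place of ethoxycarbonyl on an aromatic carbon), on an aromatic carbon of a six-membered aromatic ring of carbon only, para to a large group. The step that bears on it is the swap of a para group on the same ring between compound 2 and compound 3, which was within the scatter. No change beyond the scatter is therefore expected in this assay for compound 4: the estimated step is a number 0.6 percentage points higher from compound 3 to compound 4 (within the scatter), and compound 4 is expected to give 28%, between 13% and 43%.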

Compound 4, a percentage reported as inhibition, at one concentration (the size of the read-out at that concentration, not a potency): 20.6%
Compound 4: middle estimate off by 7.4 percentage points, on the high side, within the range that was stated.
By their numbers in this assay, from the lowest: compound 1; then compounds 4, 3 and 2 (each within the scatter of the next, the first and the last beyond it).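

Among the compounds shown here, with a third group on this aromatic carbon, a one-place step beyond the scatter appears for the first time: trifluoromethyl in place of methyl gives a number 10.7 percentage points lower from compound 2 to compound 4 (beyond the scatter), a modest change in this assay. Trifluoromethyl in place of ethoxycarbonyl gives a number 6.8 percentage points lower from compound 3 to compound 4 (within the scatter), so compound 3 cannot be told apart from compound 4 here, just as it could not be told apart from compound 2, and only the two ends of this set of three are separated. Nothing shown explains why the numbers fall this way.

The compounds shown leave open how an amine, a carboxylic acid or a longer chain on this carbon would read. They also leave open whether these same swaps would give similar steps on the core of compound 1.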